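Phenyl in Place of Dioxolanyl on a Triazole Chain

The source may hold more compounds than are shown below. What is called first, only, known or untested is meant among the compounds shown, and "the series" means these compounds.

The measured compounds, all in a functional assay on B16 cells (Mus musculus) for cytotoxicity, read by MTT assay, with a stated time of 48 h; a higher number here means a weaker inhibitor, a lower number a stronger inhibitor:
compound 1, `CC1(C)OC[C@H](Cn2cc(-c3ccc4ccccc4c3)nn2)O1`, gives 12000 nM.
compound 2, `c1ccc(Cn2cc(-c3ccc4ccccc4c3)nn2)cc1`, gives 3890 nM.
compound 3, `COc1ccc(-c2cn(C[C@H]3COC(C)(C)O3)nn2)c(OC)c1OC`, gives > 100000 nM.

The value for compound 3 is a limit of the assay, not a number, and the limit of > 100000 nM in this assay, at which 1 of the 3 values shown sits, marks where it sits.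

From compound 1 to compound 2 the change is phenyl in place of 2,2-dimethyl-1,3-dioxolan-4-yl on a saturated chain carbon bound to an aromatic nitrogen, and it gave a 3.1-fold lower number from compound 1 to compound 2 (0.49 log units; beyond the scatter).

Compound 4, `COc1ccc(-c2cn(Cc3ccccc3)nn2)c(OC)c1OC`, has not been measured. It differs from compound 3 by phenyl in place of 2,2-dimethyl-1,3-dioxolan-4-yl on a saturated chain carbon bound to an aromatic nitrogen, which is the same change in the same place. The cores of compound 1 and compound 3 differ from each other, but that difference is not broken down here.

For compound 4 the expected step is an at least 2.0-fold lower number from compound 3 to compound 4 (0.30 log units; that floor lies within the scatter), resting on compound 1 going to compound 2 by a 3.1-fold lower number from compound 1 to compound 2 (0.49 log units; beyond the scatter). On these data alone, because compound 3 stands at > 100000 nM, only a limit, the starting point is unknown, so compound 4 may also come back as a limit. Compound 4 is expected near 50000 nM, with a range from 12000 nM to 200000 nM.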

Compound 4, half-maximal inhibitory concentration: 27500 nM
The estimate for compound 4 lay 1.8-fold (0.26 log units) above the measured number; the measured number falls inside the stated range.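

In this assay, phenyl in place of 2,2-dimethyl-1,3-dioxolan-4-yl also lowers the number on the core of compound 3, with an at least 3.6-fold lower number from compound 3 to compound 4 (0.56 log units; beyond the scatter) on a saturated chain carbon bound to an aromatic nitrogen. On these data alone, compound 3 stands at > 100000 nM, which is a limit of the assay and not a number, and the full size of this step stays unknown. The change therefore carries over in direction between these two cores, but this does not show that it carries over in size: the same change on two cores in this assay, a 3.1-fold lower number (0.49 log units; beyond the scatter) from compound 1 to compound 2 and an at least 3.6-fold lower number (0.56 log units; beyond the scatter) from compound 3 to compound 4; the limit leaves it open whether they differ.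

The compounds shown leave open whether the same change holds on any other core, and whether the phenyl ring itself matters or simply the loss of 2,2-dimethyl-1,3-dioxolan-4-yl. They also leave open what a cyclohexyl group, an amine or a longer chain at the same place would do to the number.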